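This account rests on a few compounds, and the source may have more. Where it says the series, first, only, none or still open, it means among the compounds named here.

Compound 1 `CC(C)CN(NC(=O)C1CCC2(CC1)OOC1(OO2)C2CC3CC(C2)CC1C3)c1nc(C#N)ncc1Br` was tested in an ADME assay on HEK-293T cells (Homo sapiens) for cytotoxicity; a lower number here means that less compound is tolerated, a higher number that more compound is tolerated. In this assay compound 1 reaches only the limit of the test, giving > 100000 nM. Compound 2 `CC(C)CN(NC(=O)C1CCC(=O)CC1)c1nc(C#N)ncc1Br` was tested the same way, and in this assay compound 2 also reaches only a limit, at > 100000 nM. This is the limit of > 100000 nM in this assay, at which 2 of the 2 values shown sit, which marks where compound 1 stands among the numbers shown. Compound 3 `CC(C)CN(NC(=O)C1CCC2(CC1)OOC1(OO2)C2CC3CC(C2)CC1C3)c1ccnc(C#N)n1` differs from compound 1 by hydrogen in place of bromo on an aromatic carbon. Among the compounds with values here, no measured pair shows the effect of such a change, so no step beyond the scatter is expected, in either direction. For compound 3 the expected result in this assay is 100000 nM, between 30000 nM and 300000 nM, which means a step of a number no higher from compound 1 to compound 3 (the limit leaves the size open).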

Compound 3, half-maximal cytotoxic concentration: > 100000 nM
Compound 3: a limit, no number (the forecaster's own chance of this, stated with the estimate: 85%); the middle value lies on the limit itself.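

In this assay no step can be read between compound 1 and compound 3, since both stop at a limit of the test: the limit of > 100000 nM in this assay, at which 3 of the 3 values shown sit. The compounds shown leave open at what concentration any of them would become toxic to these cells, and whether swapping bromo for hydrogen changes that.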